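Methyl on the ring amine nitrogen: compound 3 to compound 4

The source may report more compounds than this note shows. Statements on the series, on what has been measured and on what is new or still open speak of the compounds shown alone.

Compound 3 `CNc1nc(NCc2ccc(C(=O)Nc3ccc(F)cc3)cc2)c2ccccc2n1` gives 4100 nM in a functional assay on SW480 cells (Homo sapiens) for inhibition, read by luminescence and resazurin assay, with a stated time of 3 days (a lower number here means a stronger inhibitor, a higher number a weaker inhibitor), the lowest of the two numbers in hand. Compound 2 `C=CCNc1nc(NCc2ccc(C(=O)Nc3ccc(F)cc3)cc2)c2cc(C)ccc2n1` gives 10000 nM in this assay. Compound 1 `CNc1nc(NCc2ccc(NC(=O)c3ccncc3)cc2)c2ccccc2n1` returns only a limit in this assay, > 20000 nM. Going by the values given here, the single measured step, an at least 4.8-fold lower number from compound 1 to compound 3 (0.68 log units; beyond the scatter), has its size set as a bound by the limit of > 20000 nM in this assay, at which 1 of the 3 values shown sits. Compound 4 `CN(C)c1nc(NCc2ccc(C(=O)Nc3ccc(F)cc3)cc2)c2ccccc2n1` carries the change (methyl in place of hydrogen on a nitrogen on an aromatic ring). Among the compounds with values here, no measured step touches this nitrogen, so nothing in hand bears on the change from compound 3 to compound 4 beyond the starting value of compound 3. For compound 4 the expected step is a 2.0-fold higher number from compound 3 to compound 4 (0.29 log units; within the scatter), held with wide uncertainty. The estimate for compound 4 in this assay is 8000 nM, between 2500 nM and 30000 nM.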

Compound 4, half-maximal inhibitory concentration: 2600 nM
Beside the measured number, compound 4's estimate is 3.1-fold (0.49 log units) above it; measured number inside the range.
By their numbers in this assay, from the lowest: compounds 4 and 3 (each within the scatter of the next); then compound 2. At a limit, above all of these: compound 1.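

Going by these compounds alone, this is the first step read at this nitrogen: in this assay, methylamino to dimethylamino gives a 1.6-fold lower number from compound 3 to compound 4 (0.20 log units; within the scatter) and cannot be told from the scatter. For this one pair, the hydrogen on this nitrogen can be replaced by methyl with no readable loss. No data in hand bear on a cause for this step.

As far as these compounds go, whether a larger group here, such as a longer chain or a morpholine, moves the number remains open. Compound 2 differs from compound 3 in more than one place, so it does not settle this.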